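Three Hydroxyls in Place of a Cyclopentyl Ring

The source may hold more compounds than are shown below. What is called first, only, known or untested is meant among the compounds shown, and "the series" means these compounds.

Compound 1 `COCCNC(=O)c1cc2cccc(OC)c2oc1=N` gives > 70% in an assay on CHO cells for displacement of a labelled ligand from adenosine receptor A1 (Homo sapiens), read by scintillation counting, with a stated time of 60 min, tested at 10 uM; a lower number here means less inhibition, a higher number more inhibition at the concentration tested (going by the name of the read-out); this is a limit of the assay, not a number.
Compound 2 `COc1cccc2cc(C(=O)NC3CCCC3)c(=N)oc12` gives > 70% in this assay; this too is a limit, not a number.
Compound 3 `COc1cccc2cc(C(=O)N[C@@H](CO)C(=O)O)c(=O)oc12` gives 12% in this assay.

Compound 2 therefore stands only at a limit, and so does compound 1: the limit of > 70% in this assay, at which 2 of the 3 values shown sit. Among the measured compounds shown here, the one step between measured compounds, a step that the two limits leave unreadable from compound 1 to compound 2, is thus unreadable in size, since both ends sit at the limit. For the measured compounds named here, compound 3 carries a different core and a different amide substituent at once, so no single step leads to it; its value shows only that a compound of this series can sit low.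

Compound 4 `COc1cccc2cc(C(=O)NC(CO)(CO)CO)c(=N)oc12` is not yet measured. It differs from compound 2 by 2-hydroxy-1,1-bis(hydroxymethyl)ethyl in place of cyclopentyl on an amide-type nitrogen. Going by the values given here, no measured step bears directly on this change: the one step available is unreadable, and compound 3 differs in two places. The expectation for compound 4 is therefore loose. Compound 4 is estimated at 45% in this assay, within 10% to 80%. The step this estimate means, a number at least 25 percentage points lower from compound 2 to compound 4 (beyond the scatter), is expected to fall below the limit of compound 2, but with wide uncertainty.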

Compound 4, a percentage reported as inhibition, at one concentration (the size of the read-out at that concentration, not a potency): 19%
The estimate for compound 4 lay 26 percentage points above the measured number, and the stated range covers the measured number.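

With the shared core held fixed, this assay now gives a readable result for a change on the amide-type nitrogen alone: 2-hydroxy-1,1-bis(hydroxymethyl)ethyl in place of cyclopentyl gives a number at least 51 percentage points lower from compound 2 to compound 4 (beyond the scatter). The same entering group in place of 2-methoxyethyl gives a number at least 51 percentage points lower from compound 1 to compound 4 (beyond the scatter), so a large fall appears from both starting points, one with a ring of carbon only and one with an open chain. Compound 3 could not show this, since it differs from the others in two places, whereas compound 4 ties a low value to the group on this nitrogen.

On these data alone, the step between compound 1 and compound 2 cannot be read, and the full size of both new steps stays open, since each starts from a limit and not from a number: the limit of > 70% in this assay, at which 2 of the 4 values shown sit. Also open, as far as these compounds go, is what in the entering group goes with the fall, its three hydroxyl groups or its branched carbon frame, a question that a tert-butyl group or a single 2-hydroxyethyl chain on the same nitrogen would help to separate.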